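The source may hold more compounds than are shown below. What is called first, only, known or untested is meant among the compounds shown, and "the series" means these compounds.

Cytotoxicity notes on the series. Compound 1 `Cc1cc(C)cc(S(=O)(=O)c2c(C(=O)N[C@@H]3CCN(Cc4ccccc4F)C3)[nH]c3ccc(Cl)cc23)c1` in an ADME assay on MT4 cells (Homo sapiens) for cytotoxicity, read by MTT assay, with a stated time of 5 days (a higher number here means that more compound is tolerated, a lower number that less compound is tolerated), gives only a limit, > 231000 nM. Compound 2 `Cc1cc(C)cc(S(=O)(=O)c2c(C(=O)N[C@@H]3CCN(Cc4ccccc4C#N)C3)[nH]c3ccc(Cl)cc23)c1` likewise gives a limit, >= 186000 nM. Within the data shown here, compound 3 `Cc1cc(C)cc(S(=O)(=O)c2c(C(=O)N[C@@H]3CCN(CC(N)=O)C3)[nH]c3ccc(Cl)cc23)c1` gives 31000 nM, the only number among the three values shown. Both measured steps run toward compound 3: an at least 7.4-fold lower number from compound 1 to compound 3 (0.87 log units; beyond the scatter) and an at least 6.0-fold lower number from compound 2 to compound 3 (0.77 log units; beyond the scatter).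

Compound 4 `Cc1cc(C)cc(S(=O)(=O)c2c(C(=O)NC3CN(Cc4n[nH]c(=O)n4C)C3)[nH]c3ccc(Cl)cc23)c1` differs from compound 3 by a group of 12 heavy atoms (7 carbon, 4 nitrogen, 1 oxygen; one four-membered non-aromatic ring with 1 hetero atom, one five-membered aromatic ring with 3 hetero atoms) in place of a group of 9 heavy atoms (6 carbon, 2 nitrogen, 1 oxygen; one five-membered non-aromatic ring with 1 hetero atom), on an amide-type nitrogen. Among the measured compounds shown here, no measured step covers a change of this kind. Because an at least 7.4-fold lower number from compound 1 to compound 3 (0.87 log units; beyond the scatter) and an at least 6.0-fold lower number from compound 2 to compound 3 (0.77 log units; beyond the scatter) both followed carbamoyl in place of an aryl group, and compound 4 keeps no aryl group either, the expected step in this assay is a 1.3-fold higher number from compound 3 to compound 4 (0.11 log units; within the scatter), not beyond the scatter. Compound 4 is thus estimated at 40000 nM, within 12000 nM to 150000 nM.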

Compound 4, half-maximal cytotoxic concentration: 25200 nM
For compound 4 the middle estimate is 1.6-fold (0.20 log units) above the measured one; the range from low to high includes it.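

In this assay, the group of 12 heavy atoms in place of 1-(carbamoylmethyl)pyrrolidin-3-yl on the amide-type nitrogen gives a 1.2-fold lower number from compound 3 to compound 4 (0.09 log units; within the scatter). The earlier steps shown here changed only the group on the saturated chain carbon, whereas this one replaces the whole group, ring included, and stays within the scatter. No measurement shown gives a cause for this result.

Going by these compounds, the ring and its end group change together here, so their separate contributions stay open. Also open, on these data alone, is how a carboxylic acid or a primary amine would read in place of the carbamoyl group.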